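This account rests on a few compounds, and the source may have more. Where it says the series, first, only, none or still open, it means among the compounds named here.

Measured compounds:
- compound 1 `COc1cc2c(Oc3ccc(NC(=O)c4cc(-c5ccc(C)cc5)ccn4)cc3F)ccnc2cc1OCCCN1CCCC1`: 1060 nM
- compound 2 `COc1cc2c(Oc3ccc(NC(=O)c4cc(-c5ccccc5C)ccn4)cc3F)ccnc2cc1OCCCN1CCCC1`: "not determined" (no result reported)

In a functional assay on A549 cells (Homo sapiens) for cytotoxicity, read by MTT assay, with a stated time of 72 h (on this read-out lower numbers stand for stronger inhibition and higher numbers for weaker inhibition), compound 1 gives 1060 nM. In this assay compound 2 gives "not determined" (no result reported); no number was reported, so compound 2 stands nowhere on the scale and cannot be placed relative to compound 1.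

Compound 3 `COc1cc2c(Oc3ccc(NC(=O)c4cc(-c5ccc(F)cc5)ccn4)cc3F)ccnc2cc1OCCCN1CCCC1` is the next member to be measured. It differs from compound 2 in one place: 4-fluorophenyl in place of 2-methylphenyl on an aromatic carbon. Because compound 2 has no value, the size and direction of the step from compound 2 to compound 3 in this assay cannot be sized from the data; there is no starting point to measure it against. Within the data shown here, the only anchor is compound 1, whose aryl group differs from that of compound 3 by a single ring substituent. In this assay compound 1 gives 1060 nM. With nothing else to go on, no shift beyond the usual scatter from that anchor is assumed.

Compound 3 is therefore expected near 1000 nM in this assay, with a plausible range from 300 nM to 4000 nM, because compound 1 gives 1060 nM.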

Compound 3, half-maximal inhibitory concentration: 1800 nM
Compound 3: the middle estimate sits 1.8-fold (0.26 log units) below what was measured; the measured number falls inside the stated range.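

In this assay, fluoro in place of methyl on the aryl group gives a 1.7-fold higher number from compound 1 to compound 3 (0.23 log units; within the scatter), the only readable step among these compounds, so this one exchange of ring substituent leaves the read-out within the usual scatter. The aryl group here sits on an aromatic carbon opposite the ring nitrogen, and the pair shows only that these two substituents on it cannot be told apart in this read-out; the step from compound 2 to compound 3 cannot be read, and 2-methylphenyl adds nothing to that picture, since compound 2 has no reported value. Nothing measured bears on why the two compounds stand where they do.

On these data alone, whether a substituent of another kind on this aryl group, such as an amine, a carboxylic acid or a longer alkyl chain, would also stay within the scatter remains open. Also open, as far as these compounds go, is what happens when the aryl group at this place gives way to a saturated ring such as piperidine, or to a bare hydrogen.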